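Trimming the chain: from compound 1 to compound 4

This account rests on a few compounds, and the source may have more. Where it says the series, first, only, none or still open, it means among the compounds named here.

Compound 1 `CCCCCCCCCCCCNC[C@@H]1OC[C@H](N)[C@H]1O` gives 2380 nM in a functional assay on PC-3 cells (Homo sapiens) for antiproliferative activity, read by MTT assay, with a stated time of 72 h (a lower number here means a stronger inhibitor, a higher number a weaker inhibitor), the highest of the three numbers in hand. Compound 2 `CCCCCCCCCCCCNC[C@@H]1OC[C@H](N)[C@@H]1O` gives 850 nM, and compound 3 `CCCCCCCCCCCCCCNC[C@@H]1OC[C@H](N)[C@@H]1O` gives 1200 nM. The step of a 2.8-fold lower number from compound 1 to compound 2 (0.45 log units; beyond the scatter) rests on (the fact that compounds 1 and 2 differ only in the configuration as drawn). The step of a 1.4-fold higher number from compound 2 to compound 3 (0.15 log units; within the scatter) is the only one that alters the chain. Compound 4 `CCCCCCCCCNC[C@@H]1OC[C@H](N)[C@H]1O` differs from compound 1 by hydrogen in place of propyl on a saturated chain carbon, nine bonds along the chain from an amine nitrogen. Since the chain step a 1.4-fold higher number from compound 2 to compound 3 (0.15 log units; within the scatter) stayed within the scatter, the change to compound 4 is expected to give no step beyond the scatter in this assay, leaning if anything toward a higher number. Compound 4 is expected to give 3500 nM, between 1500 nM and 8000 nM. The expected step is a 1.5-fold higher number from compound 1 to compound 4 (0.17 log units; within the scatter).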

Compound 4, half-maximal inhibitory concentration: 7650 nM
Compound 4: middle estimate off by 2.2-fold (0.34 log units), on the low side; low and high end bracket the measured number.
By their numbers in this assay, from the lowest: compounds 2, 3 and 1 (each within the scatter of the next, the first and the last beyond it); then compound 4.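

Hydrogen in place of propyl on a saturated chain carbon, nine bonds along the chain from an amine nitrogen, gives a 3.2-fold higher number from compound 1 to compound 4 (0.51 log units; beyond the scatter) in this assay, so the chain does respond to change in this series. The earlier chain step, a 1.4-fold higher number from compound 2 to compound 3 (0.15 log units; within the scatter), added ethyl on the configuration of compound 2 and showed no such response. No measurement in hand gives a cause for the step.

As far as these compounds go, the size of the same trimming on compound 2 remains open. So does the effect of a longer chain on compound 1, or of a chain carrying a carboxylic acid.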